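The source may report more compounds than this note shows. Statements on the series, on what has been measured and on what is new or still open speak of the compounds shown alone.

Two thiosemicarbazides built on a shared core have been measured, and a third awaits its number. Compound 1, `COc1cc(C(=O)NNC(=S)Nc2csc(-c3ccc(C)cc3)c2)cc(OC)c1OC`, carries a methyl on the phenyl group and three methoxy groups on the benzoyl side; in a functional assay on U-373MG ATCC cells (Homo sapiens) for inhibition, read by colorimetric assay and MTT assay, with a stated time of 72 h (a higher number here means a weaker inhibitor, a lower number a stronger inhibitor), compound 1 gives 47000 nM. Compound 2, `COc1ccc(C(=O)NNC(=S)Nc2csc(-c3ccccc3)c2)cc1OC`, lacks the methyl and carries two methoxy groups; in this assay compound 2 gives 59000 nM. The two compounds differ in two places, so no single step can be read between them, and their two numbers sit within the scatter of each other, so neither can be called the stronger inhibitor. Compound 3, `COc1ccc(C(=O)NNC(=S)Nc2csc(-c3ccc(C)cc3)c2)cc1OC`, is reached from compound 2 by methyl in place of hydrogen on an aromatic carbon. For the measured compounds named here, with no measured step of this kind among the pairs at hand, the change is expected to produce no shift beyond the scatter, a 1.2-fold lower number from compound 2 to compound 3 (0.07 log units; within the scatter). In this assay compound 3 is therefore estimated at 50000 nM, within a range from 25000 nM to 100000 nM.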

Compound 3, half-maximal inhibitory concentration: 47000 nM
Compound 3: middle estimate off by 1.1-fold (0.03 log units), on the high side; measured number inside the range.
By their numbers in this assay, from the lowest: compounds 1, 3 and 2 (each within the scatter of the next).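

In this assay, for the compounds shown here, the change from phenyl to 4-methylphenyl gives a 1.3-fold lower number from compound 2 to compound 3 (0.10 log units; within the scatter), the first single-place reading of a methyl on this aromatic carbon, para to a large group, and it shows no shift beyond the scatter. Hydrogen in place of methoxy on an aromatic carbon of the benzoyl side gives no change at the digits printed from compound 1 to compound 3 (within the scatter), so neither single change moves the number beyond the scatter in these pairs. Nothing available here bears on why these steps are so small.

The compounds shown carry only hydrogen or methyl at this position, which leaves open whether an amine, a carboxylic acid or a longer chain there would move the number beyond the scatter. As far as these compounds go, it is also open whether any change on the benzoyl side other than this methoxy would do so.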